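The source may hold more compounds than are shown below. What is called first, only, known or untested is meant among the compounds shown, and "the series" means these compounds.

Of the compounds shown here, two built on a shared core have been measured in a functional assay on HeLa cells (Homo sapiens) for cytotoxicity, read by sulforhodamine B assay, with a stated time of 48 h; on this read-out lower numbers stand for stronger inhibition and higher numbers for weaker inhibition. Compound 1 `C=CCOc1ccc(F)cc1C(=O)c1cccnc1` gives 93000 nM. Compound 2 `O=C(c1cccnc1)c1cc(Cl)ccc1O` gives in this assay a value of 24000 nM, the lowest of the two numbers; its nearest neighbour is compound 1, whose number is higher by a margin beyond the scatter. Going by the values given here, no single-place step joins these two compounds, as they differ in more than one place. Compound 3 `Cc1ccc(O)c(C(=O)c2cccnc2)c1` has not yet been measured in this assay. It differs from compound 2 in one place: methyl in place of chloro on an aromatic carbon. Among the compounds with values here, no measured pair shows how a methyl compares with a chloro at that place, so the expectation rests on compound 2 alone. Compound 3 is expected to stay close to compound 2, the step of a 1.5-fold higher number from compound 2 to compound 3 (0.16 log units; within the scatter) being expected to lean, if anywhere, toward a weaker value and not beyond the scatter. The estimate for compound 3 in this assay is 35000 nM, within 12000 nM to 100000 nM.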

Compound 3, half-maximal inhibitory concentration: 26000 nM
The estimate for compound 3 lay 1.3-fold (0.13 log units) above the measured number; the measured number falls inside the stated range.
By their numbers in this assay, from the lowest: compounds 2 and 3 (each within the scatter of the next); then compound 1.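

In this assay, methyl in place of chloro on this aromatic carbon, para to the hydroxy group, comes to a 1.1-fold higher number from compound 2 to compound 3 (0.03 log units; within the scatter). Going by these compounds alone, this is the first direct comparison at this position, and the read-out does not separate the two groups there, so the value seen for compound 2 is not tied to chloro alone. The data offer no explanation for this match between chloro and methyl.

Still open, from the compounds shown here alone, is whether a group of another kind at this place, such as an amine, a carboxylic acid or a longer chain, would shift the number beyond the scatter. Going by these compounds, compound 1 differs from compound 2 in more than one place, so what the hydroxy group itself contributes also remains open.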